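The source may hold more compounds than are shown below. What is called first, only, known or untested is meant among the compounds shown, and "the series" means these compounds.

Measured so far in an assay on isolated protein for inhibition of alpha-ketoglutarate-dependent dioxygenase alkB homolog 3 (Homo sapiens), read by polymerase chain reaction, with a stated time of 1 h, tested at 10 mM; a higher number here means more inhibition at the concentration tested (going by the name of the read-out), a lower number less inhibition: compound 1 `Cc1[nH]n(-c2nc3ccccc3[nH]2)c(=O)c1Cc1ccccc1Cl` gives -13%; compound 2 `Cc1[nH]n(-c2nc3ccccc3s2)c(=O)c1C` gives -3%; compound 3 `Cc1[nH]n(-c2nc3ccccc3[nH]2)c(=O)c1Cc1ccc(Cl)cc1` gives 46%.

Compound 3 stands highest of the three numbers, beyond the scatter from both compound 2 and compound 1. For the measured compounds named here, the one step that bears on the next compound is a number 59 percentage points higher from compound 1 to compound 3 (beyond the scatter), so the position of the single chloro on the phenyl ring mattered greatly. Compound 4 `Cc1[nH]n(-c2nc3ccccc3[nH]2)c(=O)c1Cc1ccc(Cl)cc1Cl` differs from compound 3 by chloro in place of hydrogen on an aromatic carbon, ortho to a large group and meta to a chloro group. Going by the values given here, compound 4 keeps the 4-chlorophenyl of compound 3 but adds the chloro that compound 1 alone carried with a low number; no measured step isolates that addition. A step of a number 16 percentage points lower from compound 3 to compound 4 (beyond the scatter) in this assay is therefore expected, downward but uncertain. Compound 4 is estimated at 30%, range 0% to 55%.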

Compound 4, a percentage reported as inhibition, at one concentration (the size of the read-out at that concentration, not a potency): 11%
For compound 4 the middle estimate is 19 percentage points above the measured one, and the stated range covers the measured number.
By their numbers in this assay, from the lowest: compounds 1 and 2 (each within the scatter of the next); then compound 4; then compound 3.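

In this assay, the chloro added to the 4-chlorophenyl gives a number 35 percentage points lower from compound 3 to compound 4 (beyond the scatter) and so costs most of the gain that the 4-chlorophenyl carried. Read from the 2-chlorophenyl side, the same 2,4-dichlorophenyl gives a number 24 percentage points higher from compound 1 to compound 4 (beyond the scatter) and so a second chloro raises the number from one starting point and lowers it from the other. Nothing on hand gives a reason for either step.

Open, on these data alone, is whether a smaller fluoro or a methyl at the position ortho to a large group would lower the number as far as chloro does. Also open, as far as these compounds go, is how an amine or a carboxylic acid on this phenyl ring would read.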